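The source may report more compounds than this note shows. Statements on the series, on what has been measured and on what is new or still open speak of the compounds shown alone.

Notes on the series.

Two compounds of the shared core carry a measurement in an ADME assay on a cell-free system (plasma, Homo sapiens) for protein binding. Compound 1 `O=C(O)CCn1c(=O)oc2cc(OCc3ccccn3)c(Cl)cc21` gives 92.6% in this assay. Compound 2 `C[C@@H](Oc1cc2c(cc1Cl)N(CCC(=O)O)C(=O)CO2)c1ccccn1` gives 92.5% in this assay. On the unbound fraction compound 1 holds the lower of the two values, and its nearest neighbour is compound 2, which lies within the scatter of it; the two values therefore show no difference that can be read as an order.

Compound 3 `O=C(O)CCn1c(=O)oc2cc(OCC3CC3)c(Cl)cc21` is not yet measured in this assay. Its structure departs from compound 1 as follows: cyclopropyl in place of pyridin-2-yl on a saturated chain carbon bound to an oxygen on an aromatic ring.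

Within the data shown here, no step between measured compounds of this kind exists for this assay, so no measured step can be carried over to compound 3. On the two values at hand, which sit close together, the step from compound 1 to compound 3 is expected to be small in this assay, if anything toward a higher bound share, and is not expected to go beyond the scatter.

For compound 3 an estimated value of 94.5% in this assay is set down, with a range from 90% to 97.5%, corresponding to an expected step of a 1.3-fold lower unbound fraction from compound 1 to compound 3 (0.13 log units; within the scatter).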

Compound 3, plasma protein binding: 96%
For compound 3 the middle estimate is 1.4-fold (0.14 log units) (unbound fraction) above the measured one; the range from low to high includes it.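

With cyclopropyl in place of pyridin-2-yl on a saturated chain carbon bound to an oxygen on an aromatic ring, the series gains its first step at this position, and the exchange gives a 1.9-fold lower unbound fraction from compound 1 to compound 3 (0.27 log units; within the scatter) in this assay for this single pair. A six-membered aromatic ring with one hetero atom and one hydrogen-bond acceptor thus gives way to a three-membered carbon-only ring with no acceptor, and the step stays inside the scatter, so this pair offers no ground for ranking the two groups on this read-out. Nothing at hand bears on what lies behind this step.

Still open, going by these compounds, is how this assay responds at this position to groups of another kind, such as an amine or a hydroxyl group carried on the chain, or a longer chain such as butoxy in place of cyclopropylmethoxy. A single pair also leaves open whether the same exchange would give a comparable step on another core, including the core of compound 2, which differs from compound 1 in more than one place.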